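This account rests on a few compounds, and the source may have more. Where it says the series, first, only, none or still open, it means among the compounds named here.

Of the compounds shown here, two have so far been measured in a functional assay on MDA-MB-231 cells (Homo sapiens) for cytotoxicity, read by MTT assay, with a stated time of 72 h; a higher number here means a weaker inhibitor, a lower number a stronger inhibitor. Compound 1 `O=Cc1cn(Cc2ccc(Cl)cc2)c2ccccc12` is a small molecule, and in this assay compound 1 gives 26100 nM. Compound 2 `CC1CCN(Cc2ccc3nc(NC(=O)N/N=C/c4cn(Cc5cccc(Cl)c5)c5ccccc45)sc3c2)CC1` is a much larger molecule that carries the core of compound 1 within it, and in this assay compound 2 gives 2110 nM. Of the two numbers shown, compound 2 holds the lower one, and its distance from compound 1 is wider than the usual scatter, so compound 2 is the stronger inhibitor of the pair.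

Compound 3 `CC1CCN(Cc2ccc3nc(NC(=O)N/N=C/c4cn(Cc5ccc(C(C)(C)C)cc5)c5ccccc45)sc3c2)CC1` has not yet been measured. It differs from compound 2 in a single place: 4-(tert-butyl)phenyl in place of 3-chlorophenyl on a saturated chain carbon bound to an aromatic nitrogen. Among the measured compounds shown here, no measured pair shows this kind of exchange, so there is no step to read it against. Both the leaving and the entering group are carbon-only aromatic rings without hydrogen-bond donors or acceptors, and the entering group is somewhat larger. The step is expected to be small, a 1.4-fold higher number from compound 2 to compound 3 (0.15 log units; within the scatter), and not clearly beyond the scatter. Compound 3 is therefore estimated at 3000 nM, with a likely range from 1000 nM to 9000 nM.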

Compound 3, half-maximal inhibitory concentration: 3880 nM
Compound 3: the middle estimate sits 1.3-fold (0.11 log units) below what was measured, and the stated range covers the measured number.
By their numbers in this assay, from the lowest: compounds 2 and 3 (each within the scatter of the next); then compound 1.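

In this assay, exchanging 3-chlorobenzyl for 4-(tert-butyl)benzyl gives a 1.8-fold higher number from compound 2 to compound 3 (0.26 log units; within the scatter), so this single change does not separate the pair. Among the compounds shown here, until now, no pair of compounds differing in only one place had been available, and this one offers a first reading of a group on a saturated chain carbon bound to an aromatic nitrogen: a 3-chlorophenyl of 7 heavy atoms and a 4-(tert-butyl)phenyl of 10 heavy atoms give values within the usual scatter of each other. No measurement available here explains why these two groups read alike.

Both groups are six-membered carbon-only aromatic rings with no hydrogen-bond donors or acceptors, and they differ in both the substituent and its place on the ring, so this one pair cannot show what each of those differences does alone. From the compounds shown here alone, how the same compound would read with a plain unsubstituted benzyl, or with a benzyl ring carrying an amine or a carboxylic acid, remains open, as does whether any change at this position can move the number beyond the scatter.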